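Three cytotoxicity limits and one expected to follow

This account rests on a few compounds, and the source may have more. Where it says the series, first, only, none or still open, it means among the compounds named here.

Measured compounds:
compound 1 `ClCc1ccc(Cn2cnc3nc(Cl)nc(Cl)c32)cc1` > 100000 nM
compound 2 `ClCc1ccccc1Cn1cnc2ncnc(Cl)c21` > 100000 nM
compound 3 `ClCc1ccccc1Cn1cnc2nc(Cl)nc(Cl)c21` > 100000 nM

In a functional assay on COLO 205 cells (Homo sapiens) for cytotoxicity, read by sulforhodamine B assay, with a stated time of 48 h (a lower number here means that less compound is tolerated, a higher number that more compound is tolerated), compound 1 gives > 100000 nM, which is a limit of the assay and not a number. Compound 2 likewise gives > 100000 nM, a limit. Compound 3 gives > 100000 nM, also a limit. The change hydrogen in place of chloro on an aromatic carbon therefore yields a step that the two limits leave unreadable from compound 3 to compound 2. Compound 1 and compound 3 contain the same atoms joined differently; the difference between the two cores is not broken down here.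

Compound 4 `ClCc1ccc(Cn2cnc3ncnc(Cl)c32)cc1` differs from compound 1 by hydrogen in place of chloro on an aromatic carbon, the same change as from compound 3 to compound 2. The step is expected to be a step that the limit leaves unreadable from compound 1 to compound 4, resting on (the limit of > 100000 nM in this assay, at which 3 of the 3 values shown sit), which all three measured compounds share. Compound 4 is estimated at 150000 nM, most probably reported again as a limit.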

Compound 4, concentration lethal to 50% of the cells: 7410 nM
Compound 4: the middle estimate sits 20-fold (1.31 log units) above what was measured; the whole stated range lies above it.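

In this assay, hydrogen in place of chloro on an aromatic carbon gives an at least 13-fold lower number from compound 1 to compound 4 (1.13 log units; beyond the scatter), so on the core of compound 1 the change comes with a large drop in the number. The same change from compound 3 to compound 2 cannot be read, so the data do not show whether this step carries over to the other core or holds only on the core of compound 1: the limit of > 100000 nM in this assay, at which 3 of the 4 values shown sit.
The partner of compound 4 on the other core is compound 2, which gives > 100000 nM, which is a limit of the assay and not a number.

The compounds shown leave open whether an amine or a methoxy group in place of the remaining chloro would keep the value of compound 4. They also leave open what a hydroxymethyl group in place of the chloromethyl group would do.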